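Swapping the Aryl Amine: From Compound 3 to Compound 4

The compounds below may be only part of what the source reports. "The series", "measured", "known", "first", "only" and "open" are said of these compounds alone.

Three compounds have been measured in a functional assay on HCC827 cells (Homo sapiens) for inhibition, read by MTT assay, with a stated time of 48 h, tested at 10 uM; on this read-out higher numbers stand for more inhibition at the one concentration tested (going by the name of the read-out) and lower numbers for less inhibition:

Compound 1, `COc1cc(NC(=O)Nc2cc(Nc3cc(Br)ccc3OC)ncn2)cc(OC)c1`, gives 76.3%.
Compound 2, `COc1cc(Br)ccc1Nc1cc(NC(=O)Nc2c(Cl)cccc2Cl)ncn1`, gives 42.7%.
Compound 3, `COc1cc(NC(=O)Nc2cc(Nc3ccc(C)c(F)c3)ncn2)cc(OC)c1`, gives 72%.

Compound 3 stands second highest of the three numbers. Its nearest neighbour is compound 1, a step of a number 4.3 percentage points lower from compound 1 to compound 3 (within the scatter), which lies within the scatter, so the two cannot be told apart. Compound 2 lies furthest away, with a value well beyond the scatter below compound 3.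

Compound 4, `COc1cc(NC(=O)Nc2cc(Nc3ccc(OC)c(I)c3)ncn2)cc(OC)c1`, has not yet been measured. It differs from compound 3 in one place: 3-iodo-4-methoxyphenyl in place of 3-fluoro-4-methylphenyl on a nitrogen on an aromatic ring.

Within the data shown here, the only measured step that bears on this change is the one from compound 1 to compound 3, where a different aryl group on the same nitrogen gave a number 4.3 percentage points lower from compound 1 to compound 3 (within the scatter), a difference within the scatter. Among the measured compounds shown here, no measured compound carries the 3-iodo-4-methoxyphenyl group, so the new group's own effect is unknown. On this slim basis, the step of no change at the digits printed from compound 3 to compound 4 (within the scatter) is expected to stay within the scatter. Compound 4 is therefore estimated to give 72% in this assay , with a range from 55% to 86%.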

Compound 4, a percentage reported as inhibition, at one concentration (the size of the read-out at that concentration, not a potency): 61.7%
For compound 4 the middle estimate is 10.3 percentage points above the measured one; the range from low to high includes it.
By their numbers in this assay, from the lowest: compound 2; then compound 4; then compounds 3 and 1 (each within the scatter of the next).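

Among these compounds, the one earlier swap on this nitrogen stayed within the scatter, which left open whether the aryl group here matters at all. Compound 4 shows that it can: 3-iodo-4-methoxyphenyl in place of 3-fluoro-4-methylphenyl gives a number 10.3 percentage points lower from compound 3 to compound 4 (beyond the scatter), and in place of 5-bromo-2-methoxyphenyl it gives a number 14.6 percentage points lower from compound 1 to compound 4 (beyond the scatter). This position therefore does not treat all the aryl groups shown alike, but nothing available here explains why.

Fluorine becomes iodine and methyl becomes methoxy in the same step, so the compounds shown cannot tell which of the two changes goes with the lower number, and a 3-fluoro-4-methoxyphenyl group would help to separate them. As far as these compounds go, how an aryl group carrying an amine or a carboxylic acid would read at this position also stays open.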